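This account rests on a few compounds, and the source may have more. Where it says the series, first, only, none or still open, it means among the compounds named here.

In a functional assay on A549 cells (Homo sapiens) for antiproliferative activity, read by MTT assay, with a stated time of 72 h (a lower number here means a stronger inhibitor, a higher number a weaker inhibitor), compound 1 `COc1cc(-c2nc(N(C)C)sc2-c2ccc3ccccc3c2)cc(OC)c1OC` gives 2900 nM. Compound 2 `COc1cc(-c2nc(N(C)C)sc2-c2ccc(C(F)(F)F)cc2)cc(OC)c1OC` reads > 10000 nM, which is a limit of the assay and not a number. Within the data shown here, the one measured step, an at least 3.4-fold higher number from compound 1 to compound 2 (0.53 log units; beyond the scatter), lies beyond the scatter and shows that the group changed there can move this read-out. Compound 3 `COc1ccc(-c2sc(N(C)C)nc2-c2cc(OC)c(OC)c(OC)c2)cc1` has methoxy in place of trifluoromethyl on an aromatic carbon, para to a large group: methoxy in place of trifluoromethyl on an aromatic carbon. Among the measured compounds shown here, no measured step covers this exchange, so its size is uncertain, but a move to a lower number in this assay is expected, with compound 1 at 2900 nM as the guide. The expected change is an at least 10-fold lower number from compound 2 to compound 3 (1.00 log units; beyond the scatter). Compound 3 is estimated at 1000 nM, with an expected range of 100 nM to 6000 nM.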

Compound 3, half-maximal inhibitory concentration: > 10000 nM
Compound 3 gave a limit, no number; the forecaster's own chance of this, stated with the estimate: 20%; middle value at least 10-fold (1.00 log units) from the limit.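

With 4-methoxyphenyl in place of naphthalen-2-yl, the result is an at least 3.4-fold higher number from compound 1 to compound 3 (0.53 log units; beyond the scatter), so the loss seen with 4-(trifluoromethyl)phenyl also appears with a second replacement at this position. Compound 3 stands at a limit of the assay, not a number, and of the three compounds only compound 1 gives a number. The exchange of trifluoromethyl for methoxy therefore cannot be read, because both compounds stand at the same limit: the limit of > 10000 nM in this assay, at which 2 of the 3 values shown sit.

Still open, as far as these compounds go, is how a 4-aminophenyl or 4-hydroxyphenyl group, or a plain phenyl, would read here. Also open, from the compounds shown here alone, is whether any group at this position gives a lower number than compound 1.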